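Extending the carbamate chain of compound 3

This account rests on a few compounds, and the source may have more. Where it says the series, first, only, none or still open, it means among the compounds named here.

Compound 3 `CCNC(=O)Oc1cccc(C(=O)c2nc3ccccc3s2)c1` gives 238 nM in an assay (strain Wistar) for inhibition of Fatty-acid amide hydrolase 1 (Rattus norvegicus) (a lower number here means a stronger inhibitor, a higher number a weaker inhibitor), the highest of the three numbers recorded here: compound 1 `CCCCNC(=O)Oc1cccc(C(=O)c2nc3ccccc3o2)c1` gives 54 nM and compound 2 `Cc1cccc(CNC(=O)Oc2cccc(C(=O)c3nc4ccccc4o3)c2)c1` gives 32 nM. Compound 4 `CCCCNC(=O)Oc1cccc(C(=O)c2nc3ccccc3s2)c1` differs from compound 3 by ethyl in place of hydrogen on a saturated chain carbon, two bonds along the chain from an amide-type nitrogen, which reads ethylamino to butylamino. Among the measured compounds shown here, the one single-change step measured, a 1.7-fold lower number from compound 1 to compound 2 (0.23 log units; within the scatter), concerns a different position and bears only loosely on this move. Compound 1 and compound 3 differ in two places, the chain and the core, so their values are suggestive rather than decisive. Still, compound 1 already carries a butyl chain at 54 nM. A modest fall is therefore expected for compound 4, a 2.2-fold lower number from compound 3 to compound 4 (0.34 log units; beyond the scatter), with an estimate of 110 nM in a range from 40 nM to 300 nM.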

Compound 4, half-maximal inhibitory concentration: 103 nM
For compound 4 the middle estimate is 1.1-fold (0.03 log units) above the measured one, and the stated range covers the measured number.
By their numbers in this assay, from the lowest: compounds 2, 1 and 4 (each within the scatter of the next, the first and the last beyond it); then compound 3.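

Going from ethylamino to butylamino on the carbamate gives a 2.3-fold lower number from compound 3 to compound 4 (0.36 log units; beyond the scatter) in this assay, a modest gain. This is the first single change among these compounds with a step beyond the scatter. It shows that the saturated chain carbon two bonds along the chain from an amide-type nitrogen accepts an added ethyl without loss of inhibition, and with some gain. What the compounds shown leave open is how a longer chain such as hexyl, or a chain ending in an amine or a carboxylic acid, would fare at this position. Nothing measured here explains the size of this step.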